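A Pyridin-4-yl Swap on a Compound at the Limit

The source may hold more compounds than are shown below. What is called first, only, known or untested is meant among the compounds shown, and "the series" means these compounds.

Of the compounds shown here, two have been tested so far in a functional assay on HL-60 cells (Homo sapiens) for cytotoxicity, read by luminescence and CellTiter-Glo, with a stated time of 3 days; a higher number here means a weaker inhibitor, a lower number a stronger inhibitor. Compound 1 (`O=C(Nc1cc(C(F)(F)F)cc(C(F)(F)F)c1)c1cc(Cl)c(F)cc1O`) gives 430 nM, a true number. Compound 2 (`COc1ccc(O)c(C(=O)Nc2ccc(C#N)cc2)c1`) gives only a limit, > 10000 nM, and no number. That limit is where one of the two results stands: the limit of > 10000 nM in this assay, at which 1 of the 2 values shown sits.

Compound 3 (`N#Cc1ccc(NC(=O)c2cc(-c3ccncc3)ccc2O)cc1`) departs from compound 2 at a single place, where pyridin-4-yl replaces methoxy on an aromatic carbon, para to a hydroxy group: pyridin-4-yl in place of methoxy on an aromatic carbon. Among the measured compounds shown here, no measured step between any two compounds is available to size this change, so any expectation is a loose one. It rests on two results: compound 2 at > 10000 nM leaves no measured starting number, and compound 1 at 430 nM shows that this assay can return a number for a compound of this set. A modest gain towards stronger inhibition is expected, though another limit would be no surprise. The expected change is an at least 2.0-fold lower number from compound 2 to compound 3 (0.30 log units; that floor lies within the scatter). For compound 3 the estimated value is 5000 nM, with an expected range from 1000 nM to 20000 nM.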

Compound 3, half-maximal inhibitory concentration: 5410 nM
Compound 3: middle estimate off by 1.1-fold (0.03 log units), on the low side; measured number inside the range.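

With compound 3 at 5410 nM in this assay, the position para to a hydroxy group proves to be one where a single change on the core of compound 2 gives a true number rather than a limit. Compound 2 gives only a limit, > 10000 nM and no number. The change from methoxy to pyridin-4-yl, which brings in a six-membered aromatic ring with 1 hetero atom, can therefore be sized from one side only: the step is an at least 1.8-fold lower number from compound 2 to compound 3 (0.26 log units; that floor lies within the scatter) and its real size could be larger, although the printed floor does not by itself go beyond the scatter.

The compounds shown leave open whether the ring nitrogen of pyridin-4-yl matters, since a plain phenyl ring, pyridin-3-yl, an amine or a carboxylic acid at the same place could each give a different number. As far as these compounds go, compound 1 differs from compound 3 in more than one place, so it offers no direct comparison, and how far this position alone can move the number remains unknown.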